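Phenyl for Ethyl on the Shared Core

This account rests on a few compounds, and the source may have more. Where it says the series, first, only, none or still open, it means among the compounds named here.

Compound 1, `CCN1C(=O)N(CC)C2C1NC(=S)N2/N=C/C=C/c1ccccc1OC`: 86100 nM
Compound 2, `CCN1C(=O)N(CC)C2C1NC(=S)N2/N=C/C=C/c1ccc(OC)cc1`: "not determined" (no result reported)

In an ADME assay on HEK293 cells (Homo sapiens) for inhibition, read by MTT assay, with a stated time of 72 h (a lower number here means a stronger inhibitor, a higher number a weaker inhibitor), compound 1 gives 86100 nM. Among the measured compounds shown here, compound 2 was tested in the same series, but in this assay compound 2 gives only "not determined" (no result reported), so compound 1 stands alone with the only measured value, and no comparison between measured compounds is available here.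

Compound 3, `CCN1C(=O)N(c2ccccc2)C2NC(=S)N(/N=C/C=C/c3ccccc3OC)C21`, differs from compound 1 by phenyl in place of ethyl on an amide-type nitrogen in a ring. For the measured compounds named here, with no measured pair to set a scale, the size of this step cannot be read from the data; the expectation is that the step from compound 1 to compound 3 is small, within or only slightly beyond the usual scatter, and if anything toward a lower number.

On that basis compound 3 is estimated at 60000 nM, within a range from 20000 nM to 180000 nM. This estimate corresponds to an expected step of a 1.4-fold lower number from compound 1 to compound 3 (0.16 log units; within the scatter).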

Compound 3, half-maximal inhibitory concentration: 57500 nM
Compound 3: middle estimate off by 1.0-fold (0.02 log units), on the high side; the range from low to high includes it.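

Among the compounds shown here, measured in this assay, phenyl in place of ethyl on an amide-type nitrogen in a ring gives a 1.5-fold lower number from compound 1 to compound 3 (0.18 log units; within the scatter) and this is the first step that can be read at all. It shows that this nitrogen can carry a six-membered aromatic ring of carbon in place of a short alkyl group with no change beyond the scatter, so the read-out of this pair does not distinguish the two groups. Nothing available here bears on why the two groups read alike.

Going by these compounds, whether the same holds for other groups on this nitrogen stays open, for instance a longer chain such as butyl, or a phenyl ring carrying an amine or a carboxylic acid. Also open, on these data alone, is whether replacing the remaining ethyl group of compound 3 would give a step of similar size.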